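Ortho substituent swap on the benzylidene arm

The source may report more compounds than this note shows. Statements on the series, on what has been measured and on what is new or still open speak of the compounds shown alone.

Measured in a functional assay on Huh-7 cells (Homo sapiens) for cytotoxicity, read by CCK-8 assay, with a stated time of 72 h; a lower number here means a stronger inhibitor, a higher number a weaker inhibitor:
compound 1 `C=CCn1c(=O)/c(=C\c2cccc(Br)c2)[nH]c(=O)/c1=C\c1ccccc1OC`: 2300 nM
compound 2 `C=CCn1c(=O)/c(=C\c2ccccc2F)[nH]c(=O)/c1=C\c1ccccc1OC`: 31300 nM
compound 3 `C=CCn1c(=O)/c(=C\c2ccccc2C(F)(F)F)[nH]c(=O)/c1=C\c1ccccc1OC`: 9500 nM

Compound 3 stands second highest of the three numbers: a 4.1-fold higher number from compound 1 to compound 3 (0.62 log units; beyond the scatter), and a 3.3-fold lower number from compound 2 to compound 3 (0.52 log units; beyond the scatter). Compound 4 `C=CCn1c(=O)/c(=C\c2ccccc2Cl)[nH]c(=O)/c1=C\c1ccccc1OC` carries the change (chloro in place of trifluoromethyl on an aromatic carbon). The step that bears most directly on it is a 3.3-fold lower number from compound 2 to compound 3 (0.52 log units; beyond the scatter), which exchanges groups on the same aromatic carbon and is modest; a 14-fold higher number from compound 1 to compound 2 (1.13 log units; beyond the scatter) and a 4.1-fold higher number from compound 1 to compound 3 (0.62 log units; beyond the scatter) also move the group to another ring position and are less comparable. A modest step in this assay is therefore expected, direction uncertain, with no strong reason to expect a large move. Compound 4 is expected at 12000 nM, range 4500 nM to 32000 nM, an expected step of a 1.3-fold higher number from compound 3 to compound 4 (0.10 log units; within the scatter).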

Compound 4, half-maximal inhibitory concentration: 6400 nM
Compound 4: the middle estimate sits 1.9-fold (0.27 log units) above what was measured; low and high end bracket the measured number.
By their numbers in this assay, from the lowest: compound 1; then compounds 4 and 3 (each within the scatter of the next); then compound 2.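

In this assay, chloro and trifluoromethyl on this aromatic carbon cannot be told apart: a 1.5-fold lower number from compound 3 to compound 4 (0.17 log units; within the scatter) stays within the scatter, despite the difference in group size counted above. Fluoro is the group that stands apart here, with a 4.9-fold lower number from compound 2 to compound 4 (0.69 log units; beyond the scatter), while a 2.8-fold higher number from compound 1 to compound 4 (0.44 log units; beyond the scatter) shows that 2-chlorophenyl does not reach compound 1. No measurement shown accounts for these differences.

Still open, going by these compounds, is how an amine or a carboxylic acid on this aromatic carbon would read. Also open, on these data alone, is whether chloro in the place of the bromo of compound 1 would match that compound.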